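This account rests on a few compounds, and the source may have more. Where it says the series, first, only, none or still open, it means among the compounds named here.

Measured in a functional assay on L1210 cells (Mus musculus) for cytotoxicity, read by MTT assay; a higher number here means a weaker inhibitor, a lower number a stronger inhibitor:
- compound 1 `O=C(N/N=C/c1ccccc1)c1cn(C2CC2)c2cc(N3CCNCC3)c(F)cc2c1=O`: 25000 nM
- compound 2 `O=C(N/N=C/c1ccc([N+](=O)[O-])cc1)c1cn(C2CC2)c2cc(N3CCNCC3)c(F)cc2c1=O`: 25000 nM

For the measured compounds named here, compound 2 stands level with compound 1, the only other compound measured so far. Compound 3 `COc1cc(/C=N/NC(=O)c2cn(C3CC3)c3cc(N4CCNCC4)c(F)cc3c2=O)cc(OC)c1OC` keeps the shared core and changes one group: 3,4,5-trimethoxyphenyl in place of 4-nitrophenyl on a carbon with a double bond to nitrogen. Going by the values given here, only one measured step bears on this, the swap of hydrogen for nitro on that aromatic ring: no change at the digits printed from compound 1 to compound 2 (within the scatter). Among the compounds with values here, no compound carrying methoxy groups has been measured, so this single step is thin evidence. Within the data shown here, with that step as the only guide, no change beyond the scatter is expected in this assay. The estimated step is a 1.1-fold lower number from compound 2 to compound 3 (0.06 log units; within the scatter). Compound 3 is expected at 22000 nM, with an estimated range of 8000 nM to 35000 nM.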

Compound 3, half-maximal inhibitory concentration: 25000 nM
Compound 3: middle estimate off by 1.1-fold (0.06 log units), on the low side, within the range that was stated.
By their numbers in this assay, from the lowest: compounds 1, 2 and 3 (each within the scatter of the next).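

In this assay, putting 3,4,5-trimethoxyphenyl in place of 4-nitrophenyl gives no change at the digits printed from compound 2 to compound 3 (within the scatter), and putting it in place of phenyl gives no change at the digits printed from compound 1 to compound 3 (within the scatter). For the compounds shown here, the earlier pair tested only a single nitro group, whereas this ring carries three methoxy groups and still gives no separation, so on this evidence the number does not respond to these ring changes on a carbon with a double bond to nitrogen. No available evidence accounts for the matching values.

On these data alone, whether an amine or a carboxylic acid on the ring, or a longer chain in its place, would shift the number remains open.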